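Carbonate chain length and half-life in the series

The compounds below may be only part of what the source reports. "The series", "measured", "known", "first", "only" and "open" are said of these compounds alone.

Measured so far in an ADME assay for pharmacokinetics, read by HPLC, in phosphate buffer, at 37 degrees C, at pH 6.0; on this read-out lower numbers stand for a shorter-lived compound and higher numbers for a longer-lived compound:
compound 1 `CCOC(=O)OCC(CO)CCn1cnc2cnc(N)nc21` gives 2690 h
compound 2 `CCCCOC(=O)OCC(CO)CCn1cnc2cnc(N)nc21` gives 1780 h

Going by the values given here, compound 2 stands at the lowest of the two numbers in this assay; its only neighbour is compound 1, and the single step between measured compounds, a 1.5-fold lower number from compound 1 to compound 2 (0.18 log units; within the scatter), lies within the scatter. Compound 3 `CCCCCOC(=O)OCC(CO)CCn1cnc2cnc(N)nc21` is not yet measured. It differs from compound 2 by methyl in place of hydrogen on a saturated chain carbon, four bonds along the chain from an oxygen next to a carbonyl group; cut one bond further out, the same difference reads methyl to ethyl, ethyl to propyl, propyl to butyl. Among the compounds with values here, only the step from compound 1 to compound 2 bears on it, a lengthening of the same chain, and that step stayed within the scatter. The step expected in this assay is therefore a 1.2-fold lower number from compound 2 to compound 3 (0.07 log units; within the scatter), a small movement downward at most, not beyond the scatter. Compound 3 is estimated at 1500 h, with a range from 800 h to 3000 h.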

Compound 3, half-life in the ADME assay: 408 h
The estimate for compound 3 lay 3.7-fold (0.57 log units) above the measured number; measured number below the stated range.
By their numbers in the ADME assay, from the lowest: compound 3; then compounds 2 and 1 (each within the scatter of the next).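

In the ADME assay, methyl in place of hydrogen four bonds along the chain from an oxygen next to a carbonyl group gives a 4.4-fold lower number from compound 2 to compound 3 (0.64 log units; beyond the scatter), and propyl in place of hydrogen two bonds along gives a 6.6-fold lower number from compound 1 to compound 3 (0.82 log units; beyond the scatter). The lengthening from compound 1 to compound 2 stayed within the scatter, so the added length does not act evenly along this chain, and the clear fall appears only at compound 3. In a physicochemical assay for solubility, read by spectrophotometry, at 20 degrees C (on this read-out lower numbers stand for lower solubility and higher numbers for higher solubility), compound 2 gives 15000 ug/mL and compound 3 gives 4200 ug/mL, so the same methyl also lowers solubility: the measured solubility of compound 2, 15000 ug/mL, and of compound 3, 4200 ug/mL, a 3.6-fold lower number (0.55 log units; beyond the scatter)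

On these data alone, whether the falls in half-life and solubility are linked stays open. A longer chain such as hexyl, or an amine at the chain end, would test whether half-life keeps falling beyond compound 3.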